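Removing One Chloro from Compound 2

The source may report more compounds than this note shows. Statements on the series, on what has been measured and on what is new or still open speak of the compounds shown alone.

Of the compounds shown here, two sharing one core have been measured in a functional assay on NB-4 cells (Homo sapiens) for inhibition, read by XTT assay, with a stated time of 48 h; a higher number here means a weaker inhibitor, a lower number a stronger inhibitor. Compound 1 `COc1ccc(C(=O)/C(=C/c2ccc(Cl)cc2)CC(C)OC(C)=O)cc1` gives 62000 nM. Compound 2 `COc1ccc(C(=O)/C(=C/c2ccc(Cl)cc2Cl)CC(C)C)cc1` gives 14600 nM, the lower of the two numbers, and its gap from compound 1 lies beyond the usual scatter. Compound 3 `COc1ccc(C(=O)/C(=C/c2ccc(Cl)cc2)CC(C)C)cc1` has not yet been measured in this assay. It differs from compound 2 in one place: hydrogen in place of chloro on an aromatic carbon, so the 2,4-dichlorophenyl of compound 2 becomes a 4-chlorophenyl in compound 3, while the rest of the molecule is kept. Going by the values given here, no measured pair shows this single change, so its effect is not known from the numbers at hand. A modest weakening is expected, and the expected step is a 2.1-fold higher number from compound 2 to compound 3 (0.31 log units; beyond the scatter), although a result within the scatter cannot be ruled out. Compound 3 is therefore estimated at 30000 nM in this assay, with a range from 12000 nM to 75000 nM.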

Compound 3, half-maximal inhibitory concentration: 12100 nM
Compound 3: middle estimate off by 2.5-fold (0.39 log units), on the high side, and the stated range covers the measured number.
By their numbers in this assay, from the lowest: compounds 3 and 2 (each within the scatter of the next); then compound 1.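

In this assay the 2,4-dichlorophenyl to 4-chlorophenyl exchange gives a 1.2-fold lower number from compound 2 to compound 3 (0.08 log units; within the scatter) and so leaves compound 2 and compound 3 indistinguishable, which shows that the chloro on this aromatic carbon, ortho to a large group, is not needed for the level seen here. Going by these compounds alone, compound 3 also supplies the first comparison on the chain that differs in one place, since methyl in place of acetoxy on the saturated chain carbon gives a 5.1-fold lower number from compound 1 to compound 3 (0.71 log units; beyond the scatter) and thus places the gap to compound 1 at that chain carbon alone. Nothing at hand explains either step.

On these data alone, whether fluoro, methoxy or an amine on that aromatic carbon would shift the number remains open. So does the outcome of a hydroxyl or a longer chain on the saturated chain carbon.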